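This account rests on a few compounds, and the source may have more. Where it says the series, first, only, none or still open, it means among the compounds named here.

Going by the values given here, in a toxicity assay on MT4 cells (Homo sapiens) for cytotoxicity, read by MTT assay (on this read-out higher numbers stand for lower toxicity in this test and lower numbers for higher toxicity in this test), compound 1 `COc1cccc(-c2cc(C)c(Oc3cc(N)nc(Nc4ccc(C#N)cc4)n3)c(C)c2)c1` gives 19300 nM and compound 2 `Cc1cc(-c2cccc(C#N)c2)cc(C)c1Oc1cc(N)nc(Nc2ccc(C#N)cc2)n1` gives 20200 nM, so compound 2 stands level with the only other measured compound, within the scatter. Compound 3 `Cc1cc(-c2ccc(C#N)cc2)cc(C)c1Oc1cc(N)nc(Nc2ccc(C#N)cc2)n1` differs from compound 2 in one place: 4-cyanophenyl in place of 3-cyanophenyl on an aromatic carbon. In words, 4-cyanophenyl stands in place of 3-cyanophenyl on an aromatic carbon. Among the compounds with values here, only one measured step bears on this change, and only indirectly: a 1.0-fold higher number from compound 1 to compound 2 (0.02 log units; within the scatter), with cyano in place of methoxy on an aromatic carbon. Within the data shown here, no measured pair shows what a move of the nitrile does. On the strength of that one small step, no change beyond the scatter is expected in this assay, and no direction can be favoured. The expected size is a 1.1-fold lower number from compound 2 to compound 3 (0.03 log units; within the scatter). For compound 3 the estimated value is 19000 nM, with an expected range from 8000 nM to 45000 nM.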

Compound 3, half-maximal cytotoxic concentration: 18100 nM
Compound 3: middle estimate off by 1.0-fold (0.02 log units), on the high side; the measured number falls inside the stated range.
By their numbers in this assay, from the lowest: compounds 3, 1 and 2 (each within the scatter of the next).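

In this assay, going by these compounds alone, 4-cyanophenyl in place of 3-cyanophenyl gives a 1.1-fold lower number from compound 2 to compound 3 (0.05 log units; within the scatter), which is the first measured pair to show what a change in the place of the nitrile does on this aromatic carbon. 4-cyanophenyl in place of 3-methoxyphenyl gives a 1.1-fold lower number from compound 1 to compound 3 (0.03 log units; within the scatter), so across these three compounds neither the kind of substituent nor its place on the phenyl group separates the numbers. No measurement shown offers an explanation for this flat result.

The compounds shown leave open whether a phenyl group carrying an amine or a carboxylic acid, or a longer chain in place of the phenyl group, would read differently at this position. They also leave open what a change elsewhere on the shared core would do, as only this one position varies among them.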